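The source may report more compounds than this note shows. Statements on the series, on what has been measured and on what is new or still open speak of the compounds shown alone.

Measured compounds:
compound 1, `Clc1ccc(Cc2nn3cc(-c4ccc(Br)cc4)nc3s2)cc1`, > 250000 nM in a functional assay on HeLa cells (Homo sapiens) for cytotoxicity, with a stated time of 72 h; a lower number here means a stronger inhibitor, a higher number a weaker inhibitor
compound 2, `Clc1ccc(Cc2nn3cc(-c4ccc(Cl)cc4Cl)nc3s2)cc1`, 109000 nM in this assay

In this assay compound 2 gives the only actual number shown. Compound 1 gives only a limit there, namely (the limit of > 250000 nM in this assay, at which 1 of the 2 values shown sits). Going by the values given here, the single measured step is an at least 2.2-fold lower number from compound 1 to compound 2 (0.36 log units; beyond the scatter). Compound 3, `Clc1ccc(Cc2nn3cc(-c4ccccc4)nc3s2)cc1`, differs from compound 2 by phenyl in place of 2,4-dichlorophenyl on an aromatic carbon. That measured step bears on it only loosely, as it too altered the halogen pattern on this ring; with both chlorines gone, a move back toward the limit is expected rather than a gain. Compound 3 is expected to give 200000 nM, within 70000 nM to 600000 nM. The expected step is a 1.8-fold higher number from compound 2 to compound 3 (0.26 log units; within the scatter).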

Compound 3, half-maximal inhibitory concentration: > 250000 nM
Compound 3: no number, only a limit; the forecaster's own chance of this, stated with the estimate: 45%; at least 1.2-fold (0.09 log units) between middle value and limit.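

In this assay, going back to phenyl gives an at least 2.2-fold higher number from compound 2 to compound 3 (0.36 log units; beyond the scatter), so of the compounds shown only the one with 2,4-dichlorophenyl on this aromatic carbon gives a measured number. The step between compound 1 and compound 3 cannot be read, so phenyl and 4-bromophenyl are not told apart here, and compound 3, like compound 1, gives only a limit: the limit of > 250000 nM in this assay, at which 2 of the 3 values shown sit.

Open, from the compounds shown here alone, is whether one chlorine alone on this ring would give the same change, and which of the two chlorines matters more. Also open, going by these compounds, is how an amine or a carboxylic acid on this ring would compare.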